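The compounds below may be only part of what the source reports. "The series", "measured", "known", "first", "only" and "open" are said of these compounds alone.

Working notes on the series. In an assay on isolated protein for inhibition of thyroid hormone receptor beta (Homo sapiens), read by fluorescence polarization (on this read-out higher numbers stand for weaker inhibition and lower numbers for stronger inhibition), compound 1 `CC1CCN(C(=O)CCCNC(=O)c2ccc(S(C)(=O)=O)c([N+](=O)[O-])c2)CC1` returns only a limit, > 60000 nM, so no number is known for it. Compound 2 `CN(CC(=O)N1CCc2ccccc2C1)C(=O)c1ccc(S(C)(=O)=O)c([N+](=O)[O-])c1` likewise returns only a limit in this assay, > 60000 nM. Going by the values given here, compound 1 therefore cannot be placed on a scale of potency: both values shown sit at the limit of > 60000 nM in this assay, at which 2 of the 2 values shown sit, and no step between measured compounds is available to calibrate the series. Compound 3 `CS(=O)(=O)c1ccc(C(=O)NCCCC(=O)N2CCCCC2)cc1[N+](=O)[O-]` differs from compound 1 by hydrogen in place of methyl on a saturated ring carbon; the rest of the shared core is unchanged. Among the compounds with values here, with no measured step in hand, no direction of effect beyond the scatter is expected for so small a change; the step expected in this assay is a number no higher from compound 1 to compound 3 (the limit leaves the size open), that is, none beyond the scatter. Compound 3 is accordingly expected to sit at 60000 nM in this assay, with a range of 20000 nM to 200000 nM, and most probably to return again a limit rather than a number.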

Compound 3, half-maximal inhibitory concentration: > 60000 nM
Compound 3 ended at the assay's limit; the forecaster's own chance of this, stated with the estimate: 90%; the middle value sits exactly at the limit.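

Going by these compounds alone, compound 1 and compound 3 both end at a limit, so no step between them can be read in this assay. The compounds shown leave open whether any change to the shared core would return a measurable number, with all of them still at: the limit of > 60000 nM in this assay, at which 3 of the 3 values shown sit.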